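The compounds below may be only part of what the source reports. "The series", "measured", "known", "first", "only" and "open" are said of these compounds alone.

Of the compounds shown here, three have been measured: compound 1 `Cc1cc(C)cc(NC(=O)COc2cc(C)nc3ccccc23)c1`, compound 2 `COc1ccc2nc(C)cc(NC(=O)C(=O)Nc3cc(C)cc(C)c3)c2c1` and compound 3 `COc1ccc2nc(C)cc(OCC(=O)Nc3c(C)cccc3C)c2c1`. In a physicochemical assay for lipophilicity, read by HPLC, in phosphate buffer, measured as chromatographic lipophilicity, at pH 7.4 (a higher number here means a more lipophilic compound, a lower number a more polar compound), compound 1 gives 5.39, compound 2 gives 6.47 and compound 3 gives 4.55, the lowest of the three numbers, lying below compound 1 by a gap beyond the scatter and still further below compound 2. Compound 4 `COc1ccc2nc(C)cc(OCC(=O)Nc3ccccn3)c2c1` awaits measurement. It differs from compound 3 in one place: pyridin-2-yl in place of 2,6-dimethylphenyl on an amide-type nitrogen. For the measured compounds named here, no measured pair shows this change, so its size rests on judgement. The expected step is a number 1.35 log units lower from compound 3 to compound 4 (beyond the scatter), downward in this assay and beyond the scatter. Compound 4 is therefore estimated at 3.2, within a range from 2.6 to 3.8.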

Compound 4, distribution coefficient: 3.49
Estimate against measurement, compound 4: 0.29 log units below; the measured number falls inside the stated range.
By their numbers in this assay, from the lowest: compound 4; then compound 3; then compound 1; then compound 2.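

In this assay pyridin-2-yl in place of 2,6-dimethylphenyl on an amide-type nitrogen gives a number 1.06 log units lower from compound 3 to compound 4 (beyond the scatter) and so shows that the group at this place, on its own, can move the number by a large step. This single pair gives the size of the step for this one change, with the rest of compound 3 held constant. Nothing given here accounts for the step.

On these data alone, the change swaps the ring and removes the methyl groups together, so the share of each remains open. An unsubstituted phenyl or a pyridin-3-yl on this nitrogen would be needed to separate them.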